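The source may hold more compounds than are shown below. What is called first, only, known or untested is meant among the compounds shown, and "the series" means these compounds.

Notes on the shared core with varied aromatic substituents, read in a functional assay on HEK293 cells for agonist activity at Free fatty acid receptor 1 (Homo sapiens), read by fluorescence and calcium flux, with a stated time of 10 min; a higher number here means that more compound is needed for the effect, a lower number that less compound is needed. Compound 1 `CC#C[C@@H](CC(=O)O)c1ccc(OC[C@H]2COc3ccc(OC(C)C)cc3O2)cc1` gives 280 nM. Compound 2 `CC#C[C@@H](CC(=O)O)c1ccc(OC[C@H]2COc3ccc(S(C)(=O)=O)cc3O2)cc1` gives 27200 nM. For compound 3 `CC#C[C@@H](CC(=O)O)c1ccc(OC[C@H]2COc3ccc(C(C)=O)cc3O2)cc1` the assay reports only a limit, > 30000 nM, which is the limit of > 30000 nM in this assay, at which 1 of the 3 values shown sits; compound 3 thus stands at the limit with no number of its own. The steps of a 97-fold higher number from compound 1 to compound 2 (1.99 log units; beyond the scatter) and an at least 100-fold higher number from compound 1 to compound 3 (2.02 log units; beyond the scatter) are both large, while an at least 1.1-fold higher number from compound 2 to compound 3 (0.04 log units; that floor lies within the scatter) cannot be sized beyond its floor. Compound 4 `CC#C[C@@H](CC(=O)O)c1ccc(OC[C@H]2COc3ccc(C(=O)N4CCOCC4)cc3O2)cc1` differs from compound 3 by morpholin-4-yl in place of methyl on a carbonyl carbon. Among the compounds with values here, no measured step covers this change at the carbonyl carbon. Compound 4 is expected to remain near the limit, an estimated step of a number no higher from compound 3 to compound 4 (the limit leaves the size open). Compound 4 is estimated at 30000 nM, within a range from 8000 nM to 100000 nM.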

Compound 4, half-maximal effective concentration: > 50000 nM
Compound 4 was reported as a limit; the forecaster's own chance of this, stated with the estimate: 60%; middle value at least 1.6-fold (0.22 log units) away from the limit.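

In this assay compound 4 also gives only a limit, with no number of its own: the limit of > 50000 nM in this assay, at which 1 of the 4 values shown sits.

Replacing isopropoxy with (morpholin-4-yl)carbonyl on this aromatic carbon gives an at least 170-fold higher number from compound 1 to compound 4 (2.25 log units; beyond the scatter), so a carbonyl bearing a ring does not restore the activity of compound 1. The other comparisons add little: an at least 1.8-fold higher number from compound 2 to compound 4 (0.26 log units; that floor lies within the scatter) has a floor within the scatter, and the step between compound 3 and compound 4 cannot be read.

Going by these compounds, it remains open whether activity at this aromatic carbon depends on the ether oxygen or on the isopropyl chain. An ethoxy or a dimethylamino group there would separate these two readings.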